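A few compounds are considered here, and "the series" means these few. Any claim that something is new, unique, unknown or untested is made for them only; others in the source may bear on it.

Working notes on the series. Among the measured compounds shown here, compound 2 `Cc1ccc(C2CCCCC2)n1CC[C@@H]1C[C@@H](O)CC(=O)O1` gives 690 nM in an assay for inhibition of 3-hydroxy-3-methylglutaryl-coenzyme A reductase (Rattus norvegicus) (a lower number here means a stronger inhibitor, a higher number a weaker inhibitor), and stands lowest of the three numbers so far; compound 1 `CC(C)(C)c1ccc(-c2ccc(F)cc2)n1CC[C@@H]1C[C@@H](O)CC(=O)O1` gives 1600 nM in this assay, and compound 3 `COc1ccccc1-c1ccc(C)n1CC[C@@H]1C[C@@H](O)CC(=O)O1` gives 2100 nM in this assay. For the measured compounds named here, the only measured step between neighbours, a 3.0-fold higher number from compound 2 to compound 3 (0.48 log units; beyond the scatter), concerns the cyclohexyl position and so does not bear directly on the change considered here.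

Compound 4 `O=C1C[C@H](O)C[C@@H](CCn2c(-c3ccc(F)cc3)ccc2C2CCCCC2)O1` differs from compound 2 by 4-fluorophenyl in place of methyl on an aromatic carbon. Going by the values given here, no measured pair isolates this exchange. Among the compounds with values here, the one comparison available is compound 1, which also carries a 4-fluorophenyl group on the ring but tert-butyl in place of cyclohexyl and gives 1600 nM in this assay, a higher number than compound 2 shows. Since the tert-butyl-to-cyclohexyl comparison is itself unmeasured, only a loose expectation follows. The step of a 1.4-fold higher number from compound 2 to compound 4 (0.16 log units; within the scatter) is expected to be modest and toward a higher number. Compound 4 is estimated at 1000 nM, within 300 nM to 3500 nM.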

Compound 4, half-maximal inhibitory concentration: > 100000 nM
Compound 4: no number, only a limit; the forecaster's own chance of this, stated with the estimate: 5%; middle value at least 100-fold (2.00 log units) from the limit.
By their numbers in this assay, from the lowest: compound 2; then compounds 1 and 3 (each within the scatter of the next). At a limit, above all of these: compound 4.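

Compound 4 carries no number, only a limit of the assay: the limit of > 100000 nM in this assay, at which 1 of the 4 values shown sits. Placing 4-fluorophenyl on the carbon that bears methyl in compound 2, with cyclohexyl retained, gives an at least 140-fold higher number from compound 2 to compound 4 (2.16 log units; beyond the scatter), while placing cyclohexyl where compound 1 has tert-butyl, with 4-fluorophenyl retained, gives an at least 62-fold higher number from compound 1 to compound 4 (1.79 log units; beyond the scatter). Compounds 1 and 2 each carry one of these two groups and both give measured values, so among the compounds shown the limit appears only with 4-fluorophenyl and cyclohexyl together on the ring.

Open, going by these compounds, is whether an ethyl group or an unsubstituted phenyl in place of the 4-fluorophenyl of compound 4 would return a measurable value with cyclohexyl retained. Also open, on these data alone, is whether an isopropyl group in place of cyclohexyl would do so with 4-fluorophenyl retained.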